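A few compounds are considered here, and "the series" means these few. Any claim that something is new, unique, unknown or untested is made for them only; others in the source may bear on it.

Measured so far:
compound 1, `CNc1nc(NCCCN(C)C)c2sc(-c3ccc(-n4cccn4)cc3)cc2n1`, gives 18.4 uL/min
compound 2, `CNc1nc(NCCCN(C)C)c2sc(-c3ccc(S(C)(=O)=O)cc3)cc2n1`, gives 15 uL/min
compound 3, `CNc1nc(NCCCN(C)C)c2sc(-c3ccc(OC)nc3)cc2n1`, gives 10 uL/min

These three share one core and differ only in the aryl group attached to it. In an ADME assay (liver) for metabolic stability, with Liver microsome (Homo sapiens) as the target, read by LC-MS, using microsomes, tested at 1 uM (a lower number here means slower removal, a higher number faster removal of the compound), compound 1 carries the largest of the three numbers, but its distance to the others is small: the step of a 1.2-fold lower number from compound 1 to compound 2 (0.09 log units; within the scatter) is within the usual scatter, and the gap between compound 1 and compound 3 is also within it, so the three compounds cannot be told apart with confidence.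

Compound 4, `CNc1nc(NCCCN(C)C)c2sc(-c3ccccc3)cc2n1`, has not yet been measured in this assay. It differs from compound 1 in one place: hydrogen in place of 1H-pyrazol-1-yl on an aromatic carbon. Among the compounds with values here, the only measured step that concerns this same position is a 1.2-fold lower number from compound 1 to compound 2 (0.09 log units; within the scatter), where one group was exchanged for another and the number hardly moved. Within the data shown here, no measured compound shows what happens when the group is removed altogether, so the expectation rests on that single nearby step and on the narrow spread of all three values. The step from compound 1 to compound 4 is therefore expected to be modest, a 1.2-fold higher number from compound 1 to compound 4 (0.08 log units; within the scatter), with a mild lean toward a higher number. Compound 4 is estimated at 22 uL/min, in the range 11 uL/min to 45 uL/min.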

Compound 4, intrinsic clearance in a liver preparation (reported as CLH), per the amount of preparation that the assay uses: 5 uL/min
The estimate for compound 4 lay 4.4-fold (0.64 log units) above the measured number; the whole stated range lies above it.
By their numbers in this assay, from the lowest: compounds 4, 3, 2 and 1 (each within the scatter of the next, the first and the last beyond it).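

Replacing the group at this position with hydrogen matters more than exchanging one group for another: in this assay the change gives a 3.7-fold lower number from compound 1 to compound 4 (0.57 log units; beyond the scatter) and a 3.0-fold lower number from compound 2 to compound 4 (0.48 log units; beyond the scatter), both beyond the usual scatter, while exchanging 1H-pyrazol-1-yl for methylsulfonyl gave only a 1.2-fold lower number from compound 1 to compound 2 (0.09 log units; within the scatter). The ring carrying only hydrogen here is therefore removed more slowly than the rings carrying either of those two groups. The pattern does not extend to compound 3, whose 6-methoxypyridin-3-yl differs from the phenyl of compound 4 by a step that stays within the scatter: a 2.0-fold lower number from compound 3 to compound 4 (0.30 log units; within the scatter).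

No available evidence explains why hydrogen at this position gives slower removal. Going by these compounds, it also remains open whether a single fluorine, a methyl or an amine at this place would behave like hydrogen or like the larger groups.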